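Flipping a Ring Stereocentre in a Glycine Transporter Inhibitor

The source may report more compounds than this note shows. Statements on the series, on what has been measured and on what is new or still open speak of the compounds shown alone.

Measured so far:
compound 1 `COc1ccc(Sc2ccc(Cl)cc2N2CCN(CC(=O)O)C(C)C2)cc1`, 290 nM
compound 2 `COc1ccc(Sc2ccccc2N2C[C@@H](C)N(CC(=O)O)C[C@@H]2C)cc1`, 160 nM
compound 3 `COc1ccc(Sc2ccccc2N2C[C@H](C)N(CC(=O)O)C[C@@H]2C)cc1`, 18000 nM

In an assay for inhibition of sodium- and chloride-dependent glycine transporter 1 (Homo sapiens) (on this read-out higher numbers stand for weaker inhibition and lower numbers for stronger inhibition), compound 2 gives the lowest number of the three, with compound 1 within the scatter and compound 3 far away. Compound 4 `COc1ccc(Sc2ccccc2N2C[C@@H](C)N(CC(=O)O)C[C@H]2C)cc1` is the next change: the two compounds have the same atoms and bonds and differ only in configuration as drawn: 1 of 2 stereo elements differ; a stereocentre at a saturated ring carbon is drawn S in compound 2 and R in compound 4. Going by the values given here, the one step that bears on this is a 110-fold higher number from compound 2 to compound 3 (2.05 log units; beyond the scatter), a loss attributable to nothing but stereochemistry because of the fact that compounds 2 and 3 differ only in the configuration as drawn. Flipping the other ring stereocentre may be equally costly, though the data cannot show that. A large weakening is therefore expected, a 16-fold higher number from compound 2 to compound 4 (1.19 log units; beyond the scatter), with wide uncertainty. Compound 4 is estimated at 2500 nM, in a range from 300 nM to 20000 nM.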

Compound 4, half-maximal inhibitory concentration: 16000 nM
For compound 4 the middle estimate is 6.4-fold (0.81 log units) below the measured one; measured number inside the range.
By their numbers in this assay, from the lowest: compounds 2 and 1 (each within the scatter of the next); then compounds 4 and 3 (each within the scatter of the next).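

The second ring stereocentre proves as sensitive as the first, with a 100-fold higher number from compound 2 to compound 4 (2.00 log units; beyond the scatter), and this loss can be traced to stereochemistry alone: the fact that compounds 2 and 4 differ only in the configuration as drawn. Compounds 3 and 4 are mirror images, yet they cannot be told apart here, with a 1.1-fold lower number from compound 3 to compound 4 (0.05 log units; within the scatter). Among these compounds, then, inverting either stereocentre of compound 2 gives a large loss, whichever of the two is changed.

Still open, on these data alone, is how the mirror image of compound 2 would read. It is also unknown whether an ethyl group on either stereocentre would be tolerated in the arrangement of compound 2.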